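The source may hold more compounds than are shown below. What is called first, only, known or untested is meant among the compounds shown, and "the series" means these compounds.

Two compounds on the shared core of compound 1 `COc1ccc(C(=O)/C=C/c2ccc(N(C)C)cc2)c2c1C=CC(C)(C)O2` carry numbers in a functional assay on HT-29 cells (Homo sapiens) for antiproliferative activity, read by MTT assay, with a stated time of 24 h; a lower number here means a stronger inhibitor, a higher number a weaker inhibitor. Compound 1 gives 1870 nM, the lowest of the two. Compound 2 `COc1ccc(C(=O)/C=C/c2ccc3ccccc3c2)c2c1C=CC(C)(C)O2` gives 4480 nM; the gap between these two values lies beyond the usual scatter, so compound 1 stands as the stronger inhibitor of the pair. Compound 3 `COc1ccccc1/C=C/C(=O)c1ccc(OC)c2c1OC(C)(C)C=C2` has not yet been measured in this assay. Set against compound 1, the change is 2-methoxyphenyl in place of 4-(dimethylamino)phenyl on a double-bonded chain carbon bound to a double-bonded chain carbon. For the measured compounds named here, no measured pair in this set shows the effect of such a change, so any expectation rests only on the two numbers in hand. An estimated step of a 2.1-fold higher number from compound 1 to compound 3 (0.33 log units; beyond the scatter) is expected, toward the weaker side, beyond the scatter yet modest. For compound 3 the estimate in this assay is 4000 nM, within a range from 1500 nM to 12000 nM.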

Compound 3, half-maximal inhibitory concentration: > 10000 nM
Compound 3: a limit, no number; the forecaster's own chance of this, stated with the estimate: 5%; middle value at least 2.5-fold (0.39 log units) from the limit.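

For the compounds shown here, on a double-bonded chain carbon bound to a double-bonded chain carbon, 2-methoxyphenyl in place of 4-(dimethylamino)phenyl gives the first step that changes one place only, read in this assay: an at least 5.3-fold higher number from compound 1 to compound 3 (0.72 log units; beyond the scatter). This position is therefore not indifferent to the group it carries, and this change moves the result toward the weaker side by more than the scatter. Compound 3 carries a limit and not a number, so the step gives only a lower bound on the size of the change: the limit of > 10000 nM in this assay, at which 1 of the 3 values shown sits.

On these data alone, the true size of the step remains open, as does whether it follows the departure of the dimethylamino group or the entry of the methoxy group. A plain phenyl or a 4-methoxyphenyl at this place would separate those two readings.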